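The source may report more compounds than this note shows. Statements on the series, on what has been measured and on what is new or still open speak of the compounds shown alone.

Measured in a functional assay on LNCaP cells (Homo sapiens) for antiproliferative activity, read by WST assay, with a stated time of 3 days; a higher number here means a weaker inhibitor, a lower number a stronger inhibitor:
Compound 1 `CCOc1c(-c2cc(OC)c(OC)c(OC)c2)oc2ccccc2c1=O`: 5400 nM
Compound 2 `CCCOc1c(-c2cc(OC)c(OC)c(OC)c2)oc2ccccc2c1=O`: 5700 nM
Compound 3 `CCCC(C)Oc1c(-c2cc(OC)c(OC)c(OC)c2)oc2ccccc2c1=O`: 15100 nM

Compound 3 is the weakest of the three in this assay, with a 2.8-fold higher number from compound 1 to compound 3 (0.45 log units; beyond the scatter) and a 2.6-fold higher number from compound 2 to compound 3 (0.42 log units; beyond the scatter). Compound 4 `CCCN(CCC)CCCCCOc1c(-c2cc(OC)c(OC)c(OC)c2)oc2ccccc2c1=O` carries 5-(dipropylamino)pentyl in place of 1-methylbutyl on an oxygen on an aromatic ring. Both modest steps lead into compound 3, whereas a 1.1-fold higher number from compound 1 to compound 2 (0.02 log units; within the scatter) stays within the scatter. Compound 4 loses the 1-methylbutyl group that came with a 2.6-fold higher number from compound 2 to compound 3 (0.42 log units; beyond the scatter), so a lower number is expected. Among the compounds with values here, no measured compound has a dipropylamino group, which leaves the size uncertain. The expected change is a 5.0-fold lower number from compound 3 to compound 4 (0.70 log units; beyond the scatter). For compound 4 the estimate is 3000 nM, with an expected range of 700 nM to 11000 nM.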

Compound 4, half-maximal inhibitory concentration: 7600 nM
The estimate for compound 4 lay 2.5-fold (0.40 log units) below the measured number; low and high end bracket the measured number.
By their numbers in this assay, from the lowest: compounds 1, 2, 4 and 3 (each within the scatter of the next, the first and the last beyond it).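

In this assay, within the data shown here, the 5-(dipropylamino)pentyl chain, the first here to carry a nitrogen, sits on the oxygen on an aromatic ring with every step to the earlier compounds within the scatter: (a 2.0-fold lower number from compound 3 to compound 4 (0.30 log units; within the scatter)), (a 1.3-fold higher number from compound 2 to compound 4 (0.12 log units; within the scatter)) and (a 1.4-fold higher number from compound 1 to compound 4 (0.15 log units; within the scatter)). So this place accepts a chain of this size with no change beyond the scatter. Nothing available explains this result.

The compounds shown leave open what the dipropylamino group contributes apart from the chain carrying it. A plain pentyl chain, or a piperidine on the same five-carbon chain, would bear on that question.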